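From compound 3 to compound 4: a new group on oxygen

The source may report more compounds than this note shows. Statements on the series, on what has been measured and on what is new or still open speak of the compounds shown alone.

In an ADME assay on a cell-free system (plasma, Homo sapiens) for protein binding, compound 3 `C[C@@H](Oc1cc2oc(=O)n(CCC(=O)O)c2cc1Cl)c1cccnn1` gives 68.1%. Compound 1 `COCCOc1cc2oc(=O)n(CCC(=O)O)c2cc1Cl` gives 70.7%, within the scatter of compound 3, while compound 2 `CCc1cc2oc(=O)n(CCC(=O)O)c2cc1Cl` gives 98.7%, far beyond it. Compound 4 `O=C(O)CCn1c(=O)oc2cc(OCc3ccccn3)c(Cl)cc21` differs from compound 3 in one place: a group of 7 heavy atoms (6 carbon, 1 nitrogen; one six-membered aromatic ring with 1 hetero atom) in place of a group of 8 heavy atoms (6 carbon, 2 nitrogen; one six-membered aromatic ring with 2 hetero atoms), on an oxygen on an aromatic ring. Among the measured compounds shown here, the closest precedent is a 1.1-fold higher unbound fraction from compound 1 to compound 3 (0.04 log units; within the scatter), a change on that same oxygen. The much larger a 23-fold lower unbound fraction from compound 1 to compound 2 (1.35 log units; beyond the scatter) replaced the whole group, oxygen included, and compound 4 keeps that oxygen. Only a small shift towards more binding is therefore expected, not one beyond the scatter. For compound 4 the expected step is a 1.5-fold lower unbound fraction from compound 3 to compound 4 (0.16 log units; within the scatter). Compound 4 is estimated at 78%, with an expected range from 62% to 92%.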

Compound 4, plasma protein binding: 92.6%
The estimate for compound 4 lay 3.0-fold (0.47 log units) (unbound fraction) above the measured number; the whole stated range lies below it.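

In this assay, the group on this oxygen proves able to move binding: with (pyridin-2-yl)methyl entering there is a 4.3-fold lower unbound fraction from compound 3 to compound 4 (0.63 log units; beyond the scatter) even though the earlier change on that oxygen stayed within the scatter. The same group also gives a 4.0-fold lower unbound fraction from compound 1 to compound 4 (0.60 log units; beyond the scatter) against the 2-methoxyethoxy compound. Replacing ethyl on the aromatic carbon still gives a 5.7-fold higher unbound fraction from compound 2 to compound 4 (0.76 log units; beyond the scatter) so the oxygen-linked groups span a real range without reaching the ethyl compound.

The compounds shown do not separate the extra ring nitrogen from the defined stereocentre, and they leave open how an amine on this oxygen would behave. No measured evidence bears on why this change moved binding.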